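Unsubstituted thiophene sulfonyl in the acyl sulfonamide series

A few compounds are considered here, and "the series" means these few. Any claim that something is new, unique, unknown or untested is made for them only; others in the source may bear on it.

Three compounds sharing a bicyclic core carrying an exocyclic allylic chain have been measured in a functional assay on CHO-K1 cells for antagonist activity at prostaglandin E2 receptor EP3 subtype (Homo sapiens), read by TR-FRET and cAMP accumulation, with a stated time of 30 min; a higher number here means a weaker inhibitor, a lower number a stronger inhibitor. Compound 1 `O=C(NS(=O)(=O)c1cc(Cl)c(Cl)s1)OC/C=C1\CCCc2cnn(Cc3ccc(Cl)cc3Cl)c21` gives 5 nM, compound 3 `O=C(NC/C=C1\CCCc2cnn(-c3ccc(C(F)(F)F)cc3)c21)NS(=O)(=O)c1cc(Cl)c(Cl)s1` gives 4 nM, and compound 2 `COc1ccc(Cl)cc1S(=O)(=O)NC(=O)NC/C=C1\CCCc2cnn(Cc3ccc(Cl)cc3Cl)c21` gives 8 nM. Compound 2 therefore has the highest number of the three, but its gaps to compound 1 and to compound 3 both lie within the usual scatter, so the three values cannot be put in order.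

Compound 4 `O=C(NC/C=C1\CCCc2cnn(Cc3ccc(Cl)cc3Cl)c21)NS(=O)(=O)c1cccs1` differs from compound 2 at the sulfonyl group: thiophen-2-yl in place of 5-chloro-2-methoxyphenyl on a sulfonyl sulfur. Among the measured compounds shown here, no measured pair in this set isolates that change, so the size of the step can only be expected, not read from data. Because compound 1 with its dichlorinated thiophene on the sulfonyl gives 5 nM and compound 3 with the same group gives 4 nM, a thiophene with no substituent is expected to lose some activity. The expected step is a 2.5-fold higher number from compound 2 to compound 4 (0.40 log units; beyond the scatter), a modest rise. Compound 4 is estimated at 20 nM, with a range from 5 nM to 80 nM.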

Compound 4, half-maximal inhibitory concentration: 28 nM
For compound 4 the middle estimate is 1.4-fold (0.15 log units) below the measured one, and the stated range covers the measured number.
By their numbers in this assay, from the lowest: compounds 3, 1 and 2 (each within the scatter of the next); then compound 4.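

Among the compounds shown here, compound 2 and compound 4 form the first pair here that differs in one place, and in this assay the change of sulfonyl group gives a 3.5-fold higher number from compound 2 to compound 4 (0.54 log units; beyond the scatter) as a modest step beyond the scatter. The group on the sulfonyl sulfur therefore affects the number, yet the 5-chloro-2-methoxyphenyl group is not required for activity, since compound 4 with the smaller thiophen-2-yl still gives 28 nM in this assay. No measurement at hand accounts for the step.

The change replaces the ring and removes the chlorine and methoxy substituents in one move, so the compounds shown cannot assign the step to any one of these. A plain phenyl on the sulfonyl sulfur, or a thiophen-2-yl carrying a single chlorine, would help to separate them.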